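A 2-Fluorophenyl Swap in a Flat Series

The compounds below may be only part of what the source reports. "The series", "measured", "known", "first", "only" and "open" are said of these compounds alone.

compound 1 `COc1cc(C2=NOC(COc3ccc(-c4nnnn4-c4cc(OC)c(OC)c(OC)c4)cc3N)C2)cc(OC)c1OC` gives 2060 nM
compound 2 `COc1ccc(C2=NOC(COc3ccc(-c4nnnn4-c4cc(OC)c(OC)c(OC)c4)cc3N)C2)cc1O` gives 2130 nM
compound 3 `COc1ccc(C2=NOC(COc3ccc(-c4nnnn4-c4cc(OC)c(OC)c(OC)c4)cc3N)C2)cc1[N+](=O)[O-]` gives 2220 nM

In a functional assay on A549 cells (Homo sapiens) for cytotoxicity, read by MTT assay, with a stated time of 48 h (on this read-out higher numbers stand for weaker inhibition and lower numbers for stronger inhibition), compound 3 gives 2220 nM and cannot be told apart from the other two compounds. Compound 4 `COc1cc(-n2nnnc2-c2ccc(OCC3CC(c4ccccc4F)=NO3)c(N)c2)cc(OC)c1OC` keeps the shared core of compound 3 but carries 2-fluorophenyl in place of 4-methoxy-3-nitrophenyl on a carbon with a double bond to nitrogen. Counted atom by atom, the change is 2-fluorophenyl in place of 4-methoxy-3-nitrophenyl on a carbon with a double bond to nitrogen and it awaits testing. For the measured compounds named here, three measured steps touch this same group: a 1.0-fold higher number from compound 1 to compound 2 (0.01 log units; within the scatter), then a 1.1-fold higher number from compound 1 to compound 3 (0.03 log units; within the scatter), and finally a 1.0-fold higher number from compound 2 to compound 3 (0.02 log units; within the scatter). All three lie within the scatter, although none of these compounds carries 2-fluorophenyl, so the new group itself remains untested. On that evidence, no step beyond the scatter is expected in this assay, in either direction. The estimated step is a 1.0-fold lower number from compound 3 to compound 4 (0.00 log units; within the scatter) and it is only a projection from those flat steps. For compound 4 the expected value is 2200 nM, with an estimated range from 1000 nM to 5000 nM.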

Compound 4, half-maximal inhibitory concentration: 1490 nM
Compound 4: the middle estimate sits 1.5-fold (0.17 log units) above what was measured; low and high end bracket the measured number.
By their numbers in this assay, from the lowest: compounds 4, 1, 2 and 3 (each within the scatter of the next).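

With 2-fluorophenyl, the ring on the carbon with a double bond to nitrogen carries fluorine as its only substituent, and the steps are a 1.5-fold lower number from compound 3 to compound 4 (0.17 log units; within the scatter) and a 1.4-fold lower number from compound 2 to compound 4 (0.16 log units; within the scatter) and a 1.4-fold lower number from compound 1 to compound 4 (0.14 log units; within the scatter) in this assay, so all three stay within the scatter. The flat picture at this position therefore extends beyond the three oxygen-bearing rings to a smaller group with 0 hydrogen-bond acceptors, at least across these four compounds. Nothing measured here bears on why the number moves so little at this position.

Still open, going by these compounds, is whether fluorine plays any part, as plain phenyl or 4-fluorophenyl would be needed to compare with compound 4. Also open, on these data alone, is whether an aminomethyl or carboxylic acid group on this ring, or a longer alkyl chain in place of the ring, would produce a step beyond the scatter.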